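The source may hold more compounds than are shown below. What is called first, only, known or untested is meant among the compounds shown, and "the series" means these compounds.

Measured in an ADME assay on Vero 76 cells (Chlorocebus sabaeus) for cytotoxicity, read by crystal violet staining, with a stated time of 96 h; on this read-out higher numbers stand for lower toxicity in this test and lower numbers for higher toxicity in this test:
- compound 1 `CCNC(=S)Nc1cccc(C(F)(F)F)c1`: > 100000 nM (a limit of the assay, not a number)
- compound 2 `FC(F)(F)c1cccc(NC(=S)Nc2cccc(Br)c2)c1`: 14000 nM

Among the measured compounds shown here, compound 2 is the only compound so far with a true number, 14000 nM. Compound 3 `FC(F)(F)c1cccc(NC(=S)NCc2ccco2)c1` follows, with (furan-2-yl)methyl in place of 3-bromophenyl on an amide-type nitrogen. For the measured compounds named here, one measured step bears on this nitrogen: an at least 7.1-fold lower number from compound 1 to compound 2 (0.85 log units; beyond the scatter), on bringing in 3-bromophenyl. Taking 3-bromophenyl out again is therefore expected to raise the number in this assay, towards lower toxicity, though (furan-2-yl)methyl is not ethyl and a smaller move is likely. The expected step is a 3.6-fold higher number from compound 2 to compound 3 (0.55 log units; beyond the scatter). Compound 3 is estimated at 50000 nM, with an expected range of 18000 nM to 100000 nM.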

Compound 3, half-maximal cytotoxic concentration: 50000 nM
Estimate against measurement, compound 3: no gap at the digits printed, within the range that was stated.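

In this assay, exchanging 3-bromophenyl for (furan-2-yl)methyl on this nitrogen gives a 3.6-fold higher number from compound 2 to compound 3 (0.55 log units; beyond the scatter), so an aromatic ring on this nitrogen does not by itself bring the number down to that of compound 2. Against the ethyl of the core of compound 1, the same position gives an at least 2.0-fold lower number from compound 1 to compound 3 (0.30 log units; that floor lies within the scatter), and that floor does not separate the two compounds beyond the scatter. Compound 1 remains a limit of the assay, not a number: the limit of > 100000 nM in this assay, at which 1 of the 3 values shown sits.

Open, as far as these compounds go, is whether the lower number of compound 2 follows the bromine or the directly attached ring; phenyl, benzyl and a longer alkyl chain on this nitrogen would bear on that.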